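From propanoyloxy to methoxy in a cytotoxicity series

A few compounds are considered here, and "the series" means these few. Any claim that something is new, unique, unknown or untested is made for them only; others in the source may bear on it.

Compound 1 `CCCC(=O)Oc1ccc2oc(/C=C/[S+](C)[O-])cc(=O)c2c1`: 8700 nM
Compound 2 `CCC(=O)Oc1ccc2oc(/C=C/[S+](C)[O-])cc(=O)c2c1`: 9000 nM

Both compounds were tested in a functional assay on DLD-1 cells (Homo sapiens) for cytotoxicity, with a stated time of 48 h; on this read-out lower numbers stand for stronger inhibition and higher numbers for weaker inhibition. For the measured compounds named here, compound 2, at 9000 nM, stands level with its only measured neighbour, compound 1, at 8700 nM. The unmeasured compound 3 `COc1ccc2oc(/C=C/[S+](C)[O-])cc(=O)c2c1` carries methyl in place of propanoyl on an oxygen on an aromatic ring. Going by the values given here, only one measured step bears on this change, and only loosely: a 1.0-fold higher number from compound 1 to compound 2 (0.01 log units; within the scatter), which stays within the scatter. That step puts hydrogen in place of methyl on a saturated chain carbon, whereas here the whole propanoyl leaves. Among the compounds with values here, no measured step shows a replacement of this kind, so the data give no firm direction. In this assay no step beyond the scatter is expected, although the uncertainty is wide. The expected change is a 1.2-fold higher number from compound 2 to compound 3 (0.09 log units; within the scatter), an estimate that leans only slightly towards a higher number. For compound 3 the estimate is 11000 nM, with an expected range from 4000 nM to 35000 nM.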

Compound 3, half-maximal inhibitory concentration: 5700 nM
Beside the measured number, compound 3's estimate is 1.9-fold (0.29 log units) above it, and the stated range covers the measured number.
By their numbers in this assay, from the lowest: compounds 3, 1 and 2 (each within the scatter of the next).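

In this assay, the earlier pair had only shortened the acyl chain, whereas compound 3 removes the whole propanoyl, carbonyl included, and places methyl on an oxygen on an aromatic ring. That larger change still gives a 1.6-fold lower number from compound 2 to compound 3 (0.20 log units; within the scatter) and, against the longer acyl group of compound 1, a 1.5-fold lower number from compound 1 to compound 3 (0.18 log units; within the scatter) in a comparison that likewise stays inside the usual variation, so at this position the read-out does not separate methoxy from either acyloxy group. No supporting evidence is available to account for this result.

The compounds shown leave open whether a free hydroxyl, an amine or a much longer chain at this oxygen would move the number beyond the scatter, since all three values lie within the scatter of the next. They also leave open whether the same indifference holds in other cell lines or for changes elsewhere on the shared core, which stays the same throughout these compounds.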